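The source may hold more compounds than are shown below. What is called first, only, known or untested is meant among the compounds shown, and "the series" means these compounds.

Series notes. The shared core carries one variable group on an aromatic carbon. Compound 1 `Cc1nc2c3ccccc3ccc2c2nc3c(ccc4ccccc43)c(-c3nccnc3N)c12` bears 3-aminopyrazin-2-yl there, and in a functional assay on HCT-116 cells (Homo sapiens) for cytotoxicity, read by MTT assay, with a stated time of 48 h (on this read-out lower numbers stand for stronger inhibition and higher numbers for weaker inhibition), compound 1 gives 3560 nM. Compound 2 `Cc1nc2c3ccccc3ccc2c2nc3c(ccc4ccccc43)c(-c3ccccc3Cl)c12` carries 2-chlorophenyl and gives 48200 nM; compound 3 `Cc1nc2c3ccccc3ccc2c2nc3c(ccc4ccccc43)c(-c3ccccc3S)c12` carries 2-sulfanylphenyl and gives 1420 nM. Compound 1 thus stands second highest of the three numbers: a 2.5-fold lower number from compound 1 to compound 3 (0.40 log units; beyond the scatter), while a 14-fold higher number from compound 1 to compound 2 (1.13 log units; beyond the scatter). The remaining step, a 34-fold lower number from compound 2 to compound 3 (1.53 log units; beyond the scatter), is the largest of the set.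

Compound 4 `Cc1nc2c3ccccc3ccc2c2nc3c(ccc4ccccc43)c(C)c12` differs from compound 1 as follows: methyl in place of 3-aminopyrazin-2-yl on an aromatic carbon. Going by the values given here, no measured step exchanges an aryl group for methyl. Among the compounds with values here, the steps that touch the variable position, a 14-fold higher number from compound 1 to compound 2 (1.13 log units; beyond the scatter) and a 2.5-fold lower number from compound 1 to compound 3 (0.40 log units; beyond the scatter), show only that swapping one ring for another moves the number either way, modestly or largely. Removing the ring altogether is a larger change than either, so a sizeable step toward weaker inhibition is expected, with wide uncertainty. For compound 4 the expected value is 15000 nM, range 3000 nM to 70000 nM. This corresponds to an expected step of a 4.2-fold higher number from compound 1 to compound 4 (0.62 log units; beyond the scatter).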

Compound 4, half-maximal inhibitory concentration: > 80000 nM
Compound 4: a limit, no number (the forecaster's own chance of this, stated with the estimate: 10%); middle value at least 5.3-fold (0.72 log units) away from the limit.
By their numbers in this assay, from the lowest: compound 3; then compound 1; then compound 2. At a limit, above all of these: compound 4.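

Compound 4 gives > 80000 nM in this assay, and this is a limit of the assay, not a number. With methyl on this aromatic carbon and no ring there, the series shows an at least 22-fold higher number from compound 1 to compound 4 (1.35 log units; beyond the scatter) and an at least 56-fold higher number from compound 3 to compound 4 (1.75 log units; beyond the scatter), so the ring-bearing compound 1 and compound 3 both sit far from the ring-free compound, which the ring-for-ring swaps could not show. Compound 2 goes against any general benefit of a ring, with an at least 1.6-fold higher number from compound 2 to compound 4 (0.22 log units; that floor lies within the scatter), so at this floor 2-chlorophenyl is not separated from methyl.

Where compound 4 truly lies past its limit stays unknown, so these steps are floors only. On these data alone, it also remains open whether an unsubstituted phenyl, an amine or a longer chain at this position would follow compound 2 or compound 3.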